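The source may report more compounds than this note shows. Statements on the series, on what has been measured and on what is new or still open speak of the compounds shown alone.

Measured compounds in an assay on CHO cells for binding affinity to Gonadotropin-releasing hormone receptor (Homo sapiens), read by radioligand binding; on this read-out higher numbers stand for weaker inhibition and lower numbers for stronger inhibition:
- compound 1, `Cc1cc(-c2c(O)nc3cc(Cl)c(C(=O)Nc4cnsn4)cc3c2OCC[C@H]2CCO2)cc(C)c1C`, gives 0.9 nM
- compound 2, `Cc1cc(-c2c(O)nc3cc(Cl)c(C(=O)Nc4ccncn4)cc3c2OCCC2CCCO2)cc(C)c1C`, gives 0.6 nM
- compound 3, `Cc1cc(-c2c(O)nc3cc(Cl)c(C(=O)Nc4cnsn4)cc3c2OCCC2CCCC2)cc(C)c1C`, gives 243 nM

Compound 3 stands at the highest of the three numbers, far from the other two. Going by the values given here, the only single change that has been measured leads to it: a 270-fold higher number from compound 1 to compound 3 (2.43 log units; beyond the scatter). So swapping a small ring that carries an oxygen for a ring of carbon only, at this position on the chain, went along with a large loss of binding.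

Compound 4, `Cc1cc(-c2c(O)nc3cc(Cl)c(C(=O)Nc4cnsn4)cc3c2OCCC2COCCN2)cc(C)c1C`, is not yet measured. It differs from compound 3 by morpholin-3-yl in place of cyclopentyl on a saturated chain carbon, two bonds along the chain from an oxygen on an aromatic ring. Among the compounds with values here, this change brings hetero atoms back into the ring at the same place on the chain, so it reverses the direction of the one step on record. The morpholin-3-yl ring is larger than the oxetan-2-yl ring of compound 1 and carries a hydrogen-bond donor, so the return need not be complete, and compound 2 shows that a somewhat larger ring with an oxygen also goes with a low number, though its amide heteroaryl differs too. A large move toward lower numbers is therefore expected, an 81-fold lower number from compound 3 to compound 4 (1.91 log units; beyond the scatter). For compound 4 the estimate is 3 nM, with a likely range from 0.5 nM to 20 nM.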

Compound 4, half-maximal inhibitory concentration: 0.7 nM
The estimate for compound 4 lay 4.3-fold (0.63 log units) above the measured number; low and high end bracket the measured number.
By their numbers in this assay, from the lowest: compounds 2, 4 and 1 (each within the scatter of the next); then compound 3.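

Going from cyclopentyl to morpholin-3-yl in this assay gives a 350-fold lower number from compound 3 to compound 4 (2.54 log units; beyond the scatter) and so shows that the large loss at this place on the chain can be recovered with a ring other than oxetan-2-yl. The second comparison, a 1.3-fold lower number from compound 1 to compound 4 (0.11 log units; within the scatter), puts the six-membered morpholin-3-yl ring level with the much smaller oxetan-2-yl ring, so among compounds 1, 3 and 4, the two rings with hetero atoms give low numbers and the carbon-only ring does not. No evidence here explains this difference.

Still open, going by these compounds, is which hetero atom matters, a question that tetrahydropyranyl, with ring oxygen alone, and piperidinyl, with ring nitrogen alone, could help settle. On these data alone, it is also open whether a ring is needed at all, or whether an open chain carrying a methoxy group or an amine could serve at this place.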